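Replacing the oxolane ring in a pyrazolopyrimidine series

The source may hold more compounds than are shown below. What is called first, only, known or untested is meant among the compounds shown, and "the series" means these compounds.

Compound 1, `COc1cc(-c2cnn3cc(OC)c(C4CCOC4)nc23)ccn1`, is one of three compounds that have so far been tested in an ADME assay on microsomes from liver (Rattus norvegicus) for metabolic stability, with a stated time of 60 min, tested at 1 uM; a higher number here means that more of the compound is left, a lower number that less of the compound is left. Compound 1 gives 34%, which is the lowest of the three numbers. Compound 3, `COc1cn2ncc(-c3ccnc(OC(C)C)c3)c2nc1-c1cnn(C)c1`, gives 50%, a result that lies beyond the scatter above that of compound 1. Compound 2, `Cn1cc(-c2nc3c(-c4ccnc(OC5CC5)c4)cnn3cc2OCCCC(C)(C)O)cn1`, gives 64%, which lies furthest from compound 1, again beyond the scatter. Compound 4, `COc1cc(-c2cnn3cc(OC)c([C@@H]4COC(C)(C)C4)nc23)ccn1`, has not yet been tested in this assay. Its structure differs from that of compound 1 in one place: a group of 7 heavy atoms (6 carbon, 1 oxygen; one five-membered non-aromatic ring with 1 hetero atom) in place of a group of 5 heavy atoms (4 carbon, 1 oxygen; one five-membered non-aromatic ring with 1 hetero atom), on an aromatic carbon. Among the compounds with values here, no step between two already measured compounds matches this change, so there is nothing directly comparable to lean on. Compound 4 is expected to stay close to compound 1, with a step from a number 4 percentage points lower from compound 1 to compound 4 (within the scatter) that should remain within the scatter or fall only slightly below it. The estimate for compound 4 is 30%, with a range from 15% to 50%.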

Compound 4, percent of the compound remaining: 30%
The estimate for compound 4 equals the measured number at the digits printed; the measured number falls inside the stated range.
By their numbers in this assay, from the lowest: compounds 4 and 1 (each within the scatter of the next); then compound 3; then compound 2.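

Within the data shown here, compound 1 and compound 4 are the first pair here that differ in one place only, so the group on the aromatic carbon next to the ring nitrogen and ortho to a methoxy group can now be read directly. In this assay, a five-membered ring of 7 heavy atoms with 1 defined stereocentre in place of oxolan-3-yl gives a number 4 percentage points lower from compound 1 to compound 4 (within the scatter), so this change leaves the two compounds indistinguishable in this assay. Nothing available explains this result.

On these data alone, it remains open whether a group of another kind at this position, such as an amine or a carboxylic acid, would give a number beyond the scatter from that of compound 1. Also open, as far as these compounds go, is whether the opposite configuration at the stereocentre of the new ring would give a number within the scatter of that of compound 4.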